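The compounds below may be only part of what the source reports. "The series", "measured", "known", "first", "only" and "open" are said of these compounds alone.

Measured compounds in an assay on membranes from HeLa cells for displacement of a labelled ligand from adenosine receptor A3 (Homo sapiens), read by scintillation counting, with a stated time of 180 min, tested at 1 uM; a higher number here means more inhibition at the concentration tested (going by the name of the read-out), a lower number less inhibition:
compound 1 `CC1=C(C(=O)OCc2ccccc2)C(c2ccoc2)NC(=S)N1` gives 20%;
compound 2 `CC1=C(C(=O)OCc2ccccc2)C(c2cccs2)NC(=S)N1` gives 24%;
compound 3 `COC(=O)C1=C(C)N(C)C(=O)NC1c1ccoc1` gives 7%.

Compound 3 stands lowest of the three in this assay. How its core differs from that of compound 1 is not broken down here.

Compound 4 `COC(=O)C1=C(C)N(C)C(=O)NC1c1cccs1` is not yet measured. It relates to compound 3 as compound 2 relates to compound 1: thiophen-2-yl in place of furan-3-yl on a saturated ring carbon gave a number 4 percentage points higher from compound 1 to compound 2 (within the scatter). For compound 4 the same kind of change is thiophen-2-yl in place of furan-3-yl on a saturated ring carbon; the surroundings of the place differ in that the neighbouring ring atom bears a methoxycarbonyl group rather than a large group, and a methyl-bearing ring atom lies three ring bonds away.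

Among the measured compounds shown here, on the one earlier step, compound 4 is expected to give 10%, between 0% and 22%. That means an estimated a number 3 percentage points higher from compound 3 to compound 4 (within the scatter), resting on compound 3 at 7%.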

Compound 4, a percentage reported as inhibition, at one concentration (the size of the read-out at that concentration, not a potency): 15%
Compound 4: middle estimate off by 5 percentage points, on the low side; the range from low to high includes it.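

In this assay, thiophen-2-yl in place of furan-3-yl on a saturated ring carbon gives a number 8 percentage points higher from compound 3 to compound 4 (within the scatter). Set beside the earlier step, the change reads alike on the two cores: the same change on two cores in this assay, a number 4 percentage points higher (within the scatter) from compound 1 to compound 2 and a number 8 percentage points higher (within the scatter) from compound 3 to compound 4, 4 percentage points apart, within the scatter of two such steps. This gives no sign that the core alters the outcome of this change, but both steps lie within the scatter, so neither shows that the change moves the read-out at all, and two cores say nothing about others.

The compounds shown leave open what a pyridyl or phenyl group would give on that saturated ring carbon. They also leave open whether a carboxylic acid in place of the methoxycarbonyl group would shift the read-out.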